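The source may report more compounds than this note shows. Statements on the series, on what has been measured and on what is new or still open speak of the compounds shown alone.

Measured compounds in a toxicity assay on Huh-7 cells (Homo sapiens) for cytotoxicity, with a stated time of 3 days; a higher number here means that more compound is tolerated, a lower number that less compound is tolerated:
Compound 1, `C[C@@]1(O)[C@H](O)[C@@H](CO)O[C@H]1n1cc(-c2ccco2)c2c(N)ncnc21`, gives 49600 nM.
Compound 2, `C[C@@]1(O)[C@H](O)[C@@H](CO)O[C@H]1n1cc(-c2cc3ccccc3o2)c2c(N)ncnc21`, gives 29400 nM.
Compound 3, `Nc1ncnc2c1c(-c1ccco1)cn2[C@H]1C[C@H](O)[C@@H](CO)O1`, gives > 44000 nM, which is a limit of this assay and not a number.

Compound 3 therefore stands at the top of the series as a limit, with the limit of > 44000 nM in this assay, at which 1 of the 3 values shown sits. Compound 4, `Nc1ncnc2c1c(-c1ccsc1)cn2[C@H]1C[C@H](O)[C@@H](CO)O1`, differs from compound 3 in one place: thiophen-3-yl in place of furan-2-yl on an aromatic carbon. Among the compounds with values here, the only measured step with a single change is a 1.7-fold lower number from compound 1 to compound 2 (0.23 log units; within the scatter), also a change of the group on an aromatic carbon, but not thiophen-3-yl in place of furan-2-yl; it lay within the scatter. Within the data shown here, no measured step bears directly on the present change, so no step beyond the scatter is expected in this assay, and a limit is again the likely outcome. Compound 4 is expected at 50000 nM, between 25000 nM and 100000 nM. The expected step is a step that the limit leaves unreadable from compound 3 to compound 4.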

Compound 4, half-maximal cytotoxic concentration: > 44000 nM
Compound 4: a limit, no number; the forecaster's own chance of this, stated with the estimate: 70%; the middle value is on the limit's open side.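

In this assay, within the data shown here, compound 3 and compound 4 both give limits and not numbers, so no step between them can be read. As far as these compounds go, whether thiophen-3-yl and furan-2-yl differ at all in this read-out stays open.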